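A few compounds are considered here, and "the series" means these few. Any claim that something is new, unique, unknown or untested is made for them only; others in the source may bear on it.

Measured so far:
- compound 1, `CCN1C(=O)C(=O)c2cc(/C=C/C(=O)OC)ccc21`: 400 nM
- compound 2, `COC(=O)/C=C/c1ccc2c(c1)/C(=N/O)C(=O)N2Cc1ccc(Br)cc1`: 9960 nM

In a functional assay on HepG2 cells (Homo sapiens) for cytotoxicity, read by MTT assay, with a stated time of 48 h (on this read-out lower numbers stand for stronger inhibition and higher numbers for weaker inhibition), compound 1 gives 400 nM, the lowest of the two numbers recorded. Compound 2 gives 9960 nM, a much higher number whose distance from compound 1 lies beyond the usual scatter; the two compounds differ in more than one place, so nothing about any single change can be read from this pair.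

Compound 3, `COC(=O)/C=C/c1ccc2c(c1)C(=O)C(=O)N2Cc1ccc(C)cc1`, has not been measured. It differs from compound 1 in one place: 4-methylphenyl in place of methyl on a saturated chain carbon bound to an amide-type nitrogen in a ring. Going by the values given here, no pair of measured compounds shows this change on its own, so the expectation rests on compound 1 alone, with the larger group entering on a saturated chain carbon bound to an amide-type nitrogen in a ring. The step from compound 1 to compound 3 is expected to be a 3.0-fold higher number from compound 1 to compound 3 (0.48 log units; beyond the scatter), a shift toward weaker inhibition that exceeds the scatter but remains moderate. Compound 3 is therefore estimated at 1200 nM, with a range from 300 nM to 5000 nM.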

Compound 3, half-maximal inhibitory concentration: 40 nM
Compound 3: middle estimate off by 30-fold (1.48 log units), on the high side; measured number below the stated range.
By their numbers in this assay, from the lowest: compound 3; then compound 1; then compound 2.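

In this assay the place on a saturated chain carbon bound to an amide-type nitrogen in a ring accepts a far larger group than methyl: 4-methylphenyl there gives a 10-fold lower number from compound 1 to compound 3 (1.00 log units; beyond the scatter) and this step lies beyond the scatter, toward stronger inhibition. Going by these compounds alone, compound 1 and compound 2 differ in more than one place, so the earlier numbers offered no reading of any single change, and this is the first step that isolates this position. The change adds one six-membered aromatic ring of carbon only and no hydrogen-bond donors or acceptors, yet no measurement at hand accounts for the lower number.

Going by these compounds, it stays open whether the step belongs to the aromatic ring as such or to the methyl on it, and whether plain phenyl, a longer alkyl chain or a dimethylamino group on that ring would give a similar number. Compound 2 cannot settle this, since it differs from compound 1 and from compound 3 in more than one place.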